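Fluoro for Hydrogen on the Fused Ring of Compound 3

This account rests on a few compounds, and the source may have more. Where it says the series, first, only, none or still open, it means among the compounds named here.

Three members of the series have been run in a physicochemical assay for pharmacokinetics, read by LC-MS, in phosphate buffer, at pH 7.4, in the presence of a further agent that is not named here; a higher number here means that the compound lasts longer, a lower number that the compound disappears faster. Compound 1 `C=CC(=O)N1CC(NC(=O)Cn2c(C)c(C(=O)N3CCc4c(cccc4OC)C3)c3cc(Br)cc(C)c32)C1` gives 1.67 h. Compound 2 `C=CC(=O)N1CC(NC(=O)COc2ccc(Br)cc2C(=O)N2CC=C(c3ccccc3)C2)C1` gives 1.67 h. Compound 3 `C=CC(=O)N1CC(NC(=O)Cn2cc(C(=O)N3CCc4ccccc4C3)c3cc(Br)ccc32)C1` gives 1.67 h. All three stand level at the digits read, and the differences among them fall within the usual scatter, so no order among compounds 1, 2 and 3 can be drawn from these numbers; compound 1 and compound 2 differ from compound 3 in more than one place, so only their values are compared here, not any single change.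

Compound 4 `C=CC(=O)N1CC(NC(=O)Cn2cc(C(=O)N3CCc4c(F)cccc4C3)c3cc(Br)ccc32)C1` is the next member, and it differs from compound 3 in one place: fluoro in place of hydrogen on an aromatic carbon. Among the compounds with values here, no step between measured compounds isolates this kind of change, so there is no measured precedent for its size in this assay. Given that three quite different compounds all sit at the same value, the change from compound 3 to compound 4 is expected to produce no shift beyond the scatter, as the step of no change at the digits printed from compound 3 to compound 4 (within the scatter) expresses. Compound 4 is therefore expected to give about 1.67 h, with a range from 1 h to 2.8 h.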

Compound 4, half-life: 1.67 h
For compound 4 middle estimate and measured number coincide at the digits printed; the measured number falls inside the stated range.
By their numbers in this assay, from the lowest: compounds 1, 2, 3 and 4 (each within the scatter of the next).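

In this assay, fluoro in place of hydrogen on an aromatic carbon, which turns the 1,2,3,4-tetrahydroisoquinolin-2-yl group into 5-fluoro-1,2,3,4-tetrahydroisoquinolin-2-yl, gives no change at the digits printed from compound 3 to compound 4 (within the scatter), and this is the only step shown that isolates one change in the series. Compounds 1 and 2 differ from compound 3 in more than one place, so their values could say nothing about any single position, whereas this step shows that, in this assay, this position takes one fluorine atom with no shift beyond the scatter. No available data bear on why the half-life holds at this position.

As far as these compounds go, the step covers one small group on one aromatic carbon, so it remains open whether an amine or a carboxylic acid on that carbon would shift the half-life beyond the scatter. From the compounds shown here alone, it also remains open whether fluoro on another carbon of the same six-membered aromatic ring would behave as it does here.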